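Acylhydrazone series on a naphthyloxyacetyl core: lipophilicity notes

This account rests on a few compounds, and the source may have more. Where it says the series, first, only, none or still open, it means among the compounds named here.

Measured so far in a physicochemical assay for lipophilicity, measured as octanol-water partition; on this read-out higher numbers stand for higher lipophilicity and lower numbers for lower lipophilicity:
compound 1 `O=C(COc1cccc2ccccc12)N/N=C/c1ccc(O)cc1` gives 3.73
compound 2 `O=C(COc1cccc2ccccc12)N/N=C/c1c(O)ccc2ccccc12` gives 4.74

Compound 1 stands lowest of the two numbers; compound 2 sits higher, beyond the scatter, so the two are distinguishable on this read-out. Nothing in the pair is a single-point step, so the two values stand on their own.

Compound 3 `O=C(COc1cccc2ccccc12)N/N=C/c1cccc(Cl)c1` is not yet measured. Against compound 1 the change is 3-chlorophenyl in place of 4-hydroxyphenyl on a carbon with a double bond to nitrogen. A hydrogen-bond donor and acceptor leave and a chlorine enters, on a carbon with a double bond to nitrogen.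

For compound 3 the step from compound 1, expected as a number 1.27 log units higher from compound 1 to compound 3 (beyond the scatter), should be upward and well beyond the scatter. Compound 3 is accordingly estimated at 5, with a range from 4.5 to 5.6.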

Compound 3, partition coefficient: 4.54
The estimate for compound 3 lay 0.46 log units above the measured number; low and high end bracket the measured number.
By their numbers in this assay, from the lowest: compound 1; then compounds 3 and 2 (each within the scatter of the next).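

In this assay the series now has its first step in one place: a modest rise of a number 0.81 log units higher from compound 1 to compound 3 (beyond the scatter) when 3-chlorophenyl takes the place of 4-hydroxyphenyl on a carbon with a double bond to nitrogen. The read-out at this position therefore responds to this exchange of aromatic groups, with the size of the step lying beyond the scatter. No supporting data bear on what lies behind the step.

Within the data shown here, the single step cannot be divided between the departing hydroxy group and the entering chlorine, so a plain phenyl group would be the informative comparison for both compound 1 and compound 3. Also open, from the compounds shown here alone, is how this position would read with a 3-aminophenyl or 3-carboxyphenyl group on the same carbon.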